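Propyl in Place of Allylsulfanyl on the Carbonyl Carbon

This account rests on a few compounds, and the source may have more. Where it says the series, first, only, none or still open, it means among the compounds named here.

Measured so far:
compound 1, `CCSC(=O)/C=C(C)/C=C/CC(C)CCCC(C)C`, 7.98
compound 2, `CC(/C=C/CC(C)CCCC(C)C)=C\C(=O)SC(C)C`, 8.39
compound 3, `C=CCSC(=O)/C=C(C)/C=C/CC(C)CCCC(C)C`, 7.97

In a physicochemical assay for lipophilicity (a lower number here means a more polar compound, a higher number a more lipophilic compound), compound 3 gives 7.97, the lowest of the three numbers, although its nearest neighbour is compound 1, and the gap a number 0.01 log units lower from compound 1 to compound 3 (within the scatter) lies within the scatter. The furthest is compound 2, and the step of a number 0.42 log units lower from compound 2 to compound 3 (beyond the scatter) is beyond the scatter.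

Compound 4, `CCCC(=O)/C=C(C)/C=C/CC(C)CCCC(C)C`, has not yet been measured. It differs from compound 3 in one place: propyl in place of allylsulfanyl on a carbonyl carbon. The measured steps touch this change only at its edge. The step of a number 0.01 log units lower from compound 1 to compound 3 (within the scatter) shows that exchanging the chain on the sulfur by a close relative hardly moves this assay. The step of a number 0.41 log units higher from compound 1 to compound 2 (beyond the scatter) and the step of a number 0.42 log units lower from compound 2 to compound 3 (beyond the scatter) show a modest swing when the chain on the sulfur changes in size. Within the data shown here, none of the measured steps removes the sulfur itself, so that part of the change is uncharted.

For compound 4 a step of a number 0.37 log units lower from compound 3 to compound 4 (beyond the scatter) in this assay is therefore expected as a tentative guess, small and downward. The estimate for compound 4 in this assay is 7.6, with a range from 7 to 8.2.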

Compound 4, partition coefficient: 6.81
Compound 4: the middle estimate sits 0.79 log units above what was measured; measured number below the stated range.
By their numbers in this assay, from the lowest: compound 4; then compounds 3 and 1 (each within the scatter of the next); then compound 2.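

With this change the carbonyl carbon emerges as a far more responsive place in this assay than the chain on the sulfur had suggested: propyl in place of allylsulfanyl gives a number 1.16 log units lower from compound 3 to compound 4 (beyond the scatter). Propyl in place of ethylsulfanyl gives a number 1.17 log units lower from compound 1 to compound 4 (beyond the scatter), and propyl in place of isopropylsulfanyl gives a number 1.58 log units lower from compound 2 to compound 4 (beyond the scatter), so all three sulfur-bearing groups shown give large steps when exchanged for propyl, whereas changing the chain on the sulfur alone reached only a number 0.42 log units lower from compound 2 to compound 3 (beyond the scatter). Among these compounds, nothing available explains why the exchange moves this number so far.

Compound 4 is the only compound shown without sulfur, so it remains open how much of these steps goes with the loss of the sulfur and how much with the particular propyl chain, and whether an ethoxy group or a methylamino group on the carbonyl carbon would fall nearer compound 4 or compound 1 in this assay. Going by these compounds, it is also open whether an isobutyl group in that place would repeat the swing seen on the sulfur.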